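The compounds below may be only part of what the source reports. "The series", "measured", "known", "first", "only" and "open" are said of these compounds alone.

Measured so far:
compound 1 `CCCC[Te]c1ccc(C(C)N)cc1` — 12.1 ug/mL
compound 2 `CCCC[Se]c1ccc(C(C)N)cc1` — > 100 ug/mL

In a functional assay, read by spectrophotometry, with a stated time of 30 min (a higher number here means a weaker inhibitor, a lower number a stronger inhibitor), compound 1 gives 12.1 ug/mL. Going by the values given here, it is the only compound here with a definite number. Compound 2, in this assay, returns > 100 ug/mL, which is a limit of the assay rather than a number. So compound 1 stands as the sole measured number, with the other value sitting at the limit of > 100 ug/mL in this assay, at which 1 of the 2 values shown sits.

Compound 3 `C=CCNC(C)c1ccc([Te]CCCC)cc1` is not yet measured. It differs from compound 1 in one place: allyl in place of hydrogen on an amine nitrogen, the cut one bond further out reading amino to allylamino. Among the compounds with values here, no step between two measured compounds is available to calibrate this change, and the tellurium part of the shared core is kept.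

The expected step from compound 1 to compound 3 in this assay is a 1.2-fold higher number from compound 1 to compound 3 (0.09 log units; within the scatter), a shift the author expects to stay near the scatter, with no direction firmly favoured. For compound 3 the estimated value in this assay is 15 ug/mL, with a range from 5 ug/mL to 50 ug/mL.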

Compound 3, half-maximal inhibitory concentration: > 100 ug/mL
Compound 3 was reported as a limit (the forecaster's own chance of this, stated with the estimate: 15%); middle value at least 6.6-fold (0.82 log units) from the limit.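

In this assay compound 3 gives > 100 ug/mL, which is a limit of the assay and not a number. Going by these compounds alone, the amine nitrogen, unchanged in the earlier compounds, now proves sensitive with the tellurium kept: allyl in place of hydrogen there gives an at least 8.2-fold higher number from compound 1 to compound 3 (0.91 log units; beyond the scatter). Compound 1 thus remains the only compound with a definite number, and the others share one limit: the limit of > 100 ug/mL in this assay, at which 2 of the 3 values shown sit.

The full size of the step stays unknown, and the compounds shown leave open whether a methyl or ethyl group on the same amine nitrogen would keep the inhibition seen for compound 1. They also leave open whether a saturated propyl chain there would behave as allyl does, which would separate the double bond from the chain itself.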